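The compounds below may be only part of what the source reports. "The series", "measured", "known", "first", "only" and "open" are said of these compounds alone.

Compound 3 `COc1ccc(Cl)cc1NS(=O)(=O)c1ccc(OC)c(N2CCNCC2)c1` gives the highest number among the three measured compounds in an assay on isolated protein for binding affinity to 5-hydroxytryptamine receptor 6 (Homo sapiens) (on this read-out lower numbers stand for stronger inhibition and higher numbers for weaker inhibition), at 1.26 nM. Compound 1 `COc1ccc(S(=O)(=O)Nc2cccc(I)c2)cc1N1CCNCC1` gives 0.501 nM in this assay, and compound 2 `COc1ccc(S(=O)(=O)Nc2cc(Br)cc(Br)c2)cc1N1CCNCC1` gives 0.501 nM. The two steps that reach compound 3 point the same way, a 2.5-fold higher number from compound 1 to compound 3 (0.40 log units; beyond the scatter) and a 2.5-fold higher number from compound 2 to compound 3 (0.40 log units; beyond the scatter), while no change at the digits printed from compound 1 to compound 2 (within the scatter). Compound 4 `COc1ccc(S(=O)(=O)Nc2ccc(Cl)c(Cl)c2)cc1N1CCNCC1` differs from compound 3 by 3,4-dichlorophenyl in place of 5-chloro-2-methoxyphenyl on a sulfonamide nitrogen. Because a 2.5-fold higher number from compound 1 to compound 3 (0.40 log units; beyond the scatter) and a 2.5-fold higher number from compound 2 to compound 3 (0.40 log units; beyond the scatter) both rose when the methoxy-bearing phenyl entered, its departure in favour of a purely chlorinated phenyl is expected to reverse that step for compound 4, a 2.1-fold lower number from compound 3 to compound 4 (0.32 log units; beyond the scatter). Compound 4 is estimated at 0.6 nM in this assay, with a range from 0.3 nM to 1.3 nM.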

Compound 4, inhibition constant: 2.51 nM
Estimate against measurement, compound 4: 4.2-fold (0.62 log units) below; the measured number lies above the stated range.
By their numbers in this assay, from the lowest: compounds 1 and 2 (each within the scatter of the next); then compounds 3 and 4 (each within the scatter of the next).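

In this assay the change on a sulfonamide nitrogen from 5-chloro-2-methoxyphenyl to 3,4-dichlorophenyl gives a 2.0-fold higher number from compound 3 to compound 4 (0.30 log units; within the scatter). This does not bring the number of compound 4 back to the level of compounds 1 and 2. Against 3,5-dibromophenyl the same group gives a 5.0-fold higher number from compound 2 to compound 4 (0.70 log units; beyond the scatter) and against 3-iodophenyl it gives a 5.0-fold higher number from compound 1 to compound 4 (0.70 log units; beyond the scatter) so the absence of a methoxy group alone does not yield the low numbers of those two compounds. Nothing available explains these steps. Still open, as far as these compounds go, is whether iodine or bromine itself accounts for the low numbers, and how an amine or a carboxylic acid on this phenyl would read.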